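Dicyano core series: amine-bearing side chain to propyl

The source may hold more compounds than are shown below. What is called first, only, known or untested is meant among the compounds shown, and "the series" means these compounds.

Among the measured compounds shown here, compound 2 `CCN(CC)CCn1c(N)c(-c2nc3ccccc3[nH]2)c2nc(C#N)c(C#N)nc21` gives 2490 nM in a functional assay on K562 cells (Homo sapiens) for antiproliferative activity, read by MTT assay, with a stated time of 48 h (a higher number here means a weaker inhibitor, a lower number a stronger inhibitor), the lowest of the two numbers measured so far; compound 1 `CN(C)CCn1c(N)c(-c2nc3ccccc3[nH]2)c2nc(C#N)c(C#N)nc21` gives 6340 nM, and the two are separated by a 2.5-fold lower number from compound 1 to compound 2 (0.41 log units; beyond the scatter). Compound 3 `CCCn1c(N)c(-c2nc3ccccc3[nH]2)c2nc(C#N)c(C#N)nc21` differs from compound 2 by methyl in place of diethylamino on a saturated chain carbon, two bonds along the chain from an aromatic nitrogen. For the measured compounds named here, the only measured step at this place, a 2.5-fold lower number from compound 1 to compound 2 (0.41 log units; beyond the scatter), exchanged one amine for another and kept the single acceptor, so it bears on the present change only loosely; no measured step removes the amine altogether. Going by the values given here, the direction of the step is therefore open, and a move beyond the scatter in either sense is possible, with a weaker inhibitor somewhat more likely given that the series so far has carried the amine. Compound 3 is expected to give 5000 nM in this assay, with a range from 1500 nM to 20000 nM. That corresponds to an expected step of a 2.0-fold higher number from compound 2 to compound 3 (0.30 log units; within the scatter).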

Compound 3, half-maximal inhibitory concentration: > 50000 nM
Compound 3: a limit, no number; the forecaster's own chance of this, stated with the estimate: 10%; middle value at least 10-fold (1.00 log units) from the limit.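

In this assay compound 3 gives > 50000 nM, which is a limit of the assay and not a number. The earlier step only exchanged one amine for another, a 2.5-fold lower number from compound 1 to compound 2 (0.41 log units; beyond the scatter), whereas replacing the amine outright, 2-(diethylamino)ethyl to propyl, gives an at least 20-fold higher number from compound 2 to compound 3 (1.30 log units; beyond the scatter), and the same replacement of dimethylamino by methyl gives an at least 7.8-fold higher number from compound 1 to compound 3 (0.89 log units; beyond the scatter). Among these three compounds, then, the presence of an amine on the chain counts for more in this assay than the choice between the two amines, with no compound going against this.

Still open, from the compounds shown here alone, is whether a hydroxyl group, a primary amine or a ring amine such as morpholine on the same chain would hold the activity. Also open, going by these compounds, is how a longer chain carrying the amine would read.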